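Carbamoyl for hydroxy on two purine-linked serine amides

The source may report more compounds than this note shows. Statements on the series, on what has been measured and on what is new or still open speak of the compounds shown alone.

Measured compounds:
compound 1, `O=C(CN(c1nc(Cl)nc2[nH]cnc12)C1CC1)N[C@@H](CO)C(=O)O`, 18.8%
compound 2, `NC(=O)C[C@H](NC(=O)CN(c1nc(Cl)nc2[nH]cnc12)C1CC1)C(=O)O`, 7.51%
compound 3, `O=C(CN(c1ncnc2c1ncn2C1CCCCO1)C1CC1)N[C@@H](CO)C(=O)OCc1ccccc1`, 18.3%

Of the compounds shown here, three have been tested in a functional assay on the whole organism (Tail, strain ICR) with Mus musculus as the target, in the tail flick test, with a stated time of 150 min, at a dose of 25 umol/kg by the oral route; on this read-out lower numbers stand for a weaker effect and higher numbers for a stronger effect at the one dose given. Compound 1 gives 18.8%, and compound 2, which carries carbamoyl in place of hydroxy on a saturated chain carbon, two bonds along the chain from an amide-type nitrogen and a carbonyl carbon, gives 7.51%; the step of a number 11.3 percentage points lower from compound 1 to compound 2 (beyond the scatter). Compound 3 gives 18.3%; its core differs from that of compound 1 in a way not broken down here, and its value and that of compound 1 lie within the scatter of each other.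

Compound 4, `NC(=O)C[C@H](NC(=O)CN(c1ncnc2c1ncn2C1CCCCO1)C1CC1)C(=O)OCc1ccccc1`, is not yet measured. It differs from compound 3 by carbamoyl in place of hydroxy on a saturated chain carbon, two bonds along the chain from an amide-type nitrogen and a carbonyl carbon, and the place is described in the same words as for the pair of compound 1 and compound 2, so it is the same change made on the other core. For the measured compounds named here, on the strength of the single earlier step of a number 11.3 percentage points lower from compound 1 to compound 2 (beyond the scatter), a comparable downward step is expected, a number 10.3 percentage points lower from compound 3 to compound 4 (beyond the scatter), though one example gives only a loose anchor. Compound 4 is therefore estimated at 8%, with a range from 0% to 18%.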

Compound 4, a percentage reported as activity, at one dose (the size of the read-out at that dose, not a potency): 21.7%
Compound 4: the middle estimate sits 13.7 percentage points below what was measured; measured number outside the range, above it.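

On the core of compound 3, putting carbamoyl in place of hydroxy in this assay gives a number 3.4 percentage points higher from compound 3 to compound 4 (within the scatter), so this core shows no drop of the kind seen on the core of compound 1. For the compounds shown here, the change therefore does not carry over from one core to the other with a single size or direction in this small series: the same change on two cores in this assay, a number 11.3 percentage points lower (beyond the scatter) from compound 1 to compound 2 and a number 3.4 percentage points higher (within the scatter) from compound 3 to compound 4, 14.7 percentage points apart, beyond the scatter of two such steps This shows that the result of the change depends on the core it is made on, but with only two pairs it does not show which of the differences between the cores goes with the gap, nor what the change would do on any third core.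

Going by these compounds, what a carboxylic acid or an amine at this place would give remains open, as does the effect of a longer chain carrying the carbamoyl. On these data alone, each pair is also read at a single dose and time, so it remains open whether the gap between the two steps would hold under other conditions.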